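A few compounds are considered here, and "the series" means these few. Any claim that something is new, unique, unknown or untested is made for them only; others in the source may bear on it.

Compound 1 `COc1ccc(/C=C\c2cc(OC)c(OC)c(OC)c2)cc1OCc1ccc(CN2CCCC[C@@H]2C(=O)O)cc1` carries a 2-carboxypiperidin-1-yl group on a saturated chain carbon bound to an aromatic carbon. In an ADME assay on NCM460 cells (Homo sapiens) for cytotoxicity, read by CCK-8 assay, with a stated time of 48 h (a higher number here means a weaker inhibitor, a lower number a stronger inhibitor), compound 1 gives > 50000 nM, which is a limit of the assay rather than a number, namely (the limit of > 50000 nM in this assay, at which 1 of the 2 values shown sits). Going by the values given here, its single measured neighbour, compound 2 `COc1ccc(/C=C\c2cc(OC)c(OC)c(OC)c2)cc1OCc1ccc(CNCCN(C)C)cc1`, has (2-(dimethylamino)ethyl)amino in that place, and in this assay compound 2 gives 35000 nM. The step of an at least 1.4-fold lower number from compound 1 to compound 2 (0.15 log units; that floor lies within the scatter) therefore sets only a floor, and that floor lies within the scatter, so no real movement is shown. Compound 3 `COc1ccc(/C=C\c2cc(OC)c(OC)c(OC)c2)cc1OCc1ccc(CN2CC[C@@H](O)C2)cc1` differs from compound 1 by 3-hydroxypyrrolidin-1-yl in place of 2-carboxypiperidin-1-yl on a saturated chain carbon bound to an aromatic carbon. Among the compounds with values here, only the step from compound 1 to compound 2 bears on this change, and it shows that replacing the amine at this position left the number near the limit. Compound 3 is accordingly expected to show no step beyond the scatter, an at least 1.1-fold lower number from compound 1 to compound 3 (0.04 log units; that floor lies within the scatter). The estimate for compound 3 is 45000 nM, with a range from 20000 nM to 100000 nM.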

Compound 3, half-maximal inhibitory concentration: 53000 nM
Estimate against measurement, compound 3: 1.2-fold (0.07 log units) below; measured number inside the range.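

In this assay, going by these compounds alone, the first step at this position with a number at both ends is a 1.5-fold higher number from compound 2 to compound 3 (0.18 log units; within the scatter), so exchanging the (2-(dimethylamino)ethyl)amino group for the 3-hydroxypyrrolidin-1-yl ring shows no real movement. This gives the position a first readable comparison, and no readable step here lies beyond the scatter. The step from compound 1 to compound 3 cannot be read because compound 1 stands at a limit of the assay: the limit of > 50000 nM in this assay, at which 1 of the 3 values shown sits.

On these data alone, it remains open whether a primary amine, a morpholine ring or a longer chain on this saturated chain carbon would move the number beyond the scatter. Also open, as far as these compounds go, is how the mirror-image form of 3-hydroxypyrrolidin-1-yl, or a carboxylic acid on the five-membered ring, would read in this assay.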